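Three Compounds Measured, a Fourth Awaiting Its Cytotoxicity Value

The source may hold more compounds than are shown below. What is called first, only, known or untested is meant among the compounds shown, and "the series" means these compounds.

Compound 1, `N/N=C1\C(=O)Nc2ccc(S(=O)(=O)N3CCOCC3)cc21`, gives 391000 nM.
Compound 2, `O=C1Nc2ccc(S(=O)(=O)N3CCOCC3)cc2/C1=N/NC(=O)c1ccccc1`, gives 295000 nM.
Compound 3, `O=C1Nc2ccc(S(=O)(=O)N3CCOCC3)cc2/C1=N/c1ccc(O)cc1`, gives 259000 nM.

These three values come from an ADME assay on WI-38 cells (Homo sapiens) for cytotoxicity, read by sulforhodamine B assay, with a stated time of 24 h; a higher number here means a weaker inhibitor, a lower number a stronger inhibitor. Compound 2 stands second highest of the three numbers; its nearest neighbour is compound 3, separated by a 1.1-fold lower number from compound 2 to compound 3 (0.06 log units; within the scatter), and its furthest is compound 1, the step of a 1.3-fold lower number from compound 1 to compound 2 (0.12 log units; within the scatter) being likewise within the scatter. Among the measured compounds shown here, all three compounds share the same core, and none of the measured steps leaves the scatter.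

Compound 4, `O=C1Nc2ccc(S(=O)(=O)N3CCOCC3)cc2/C1=N/c1cccc(C(F)(F)F)c1`, has not yet been measured in this assay. Relative to compound 2 the change is 3-(trifluoromethyl)phenyl in place of benzamido on a double-bonded nitrogen. For the measured compounds named here, the step that bears most directly on this change is the one between compound 2 and compound 3, because compound 3 also places an aryl ring on that double-bonded nitrogen: a 1.1-fold lower number from compound 2 to compound 3 (0.06 log units; within the scatter). The step of a 1.5-fold lower number from compound 1 to compound 3 (0.18 log units; within the scatter), which also introduces an aryl ring on the same nitrogen, is within the scatter as well. No step beyond the scatter is therefore expected for compound 4 in this assay.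

Compound 4 is estimated at 270000 nM, within a range from 130000 nM to 560000 nM. The step this estimate implies is expected to be a 1.1-fold lower number from compound 2 to compound 4 (0.04 log units; within the scatter).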

Compound 4, half-maximal inhibitory concentration: 226000 nM
For compound 4 the middle estimate is 1.2-fold (0.08 log units) above the measured one, and the stated range covers the measured number.
By their numbers in this assay, from the lowest: compounds 4, 3, 2 and 1 (each within the scatter of the next).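

In this assay, the replacement of benzamido by 3-(trifluoromethyl)phenyl on a double-bonded nitrogen, which removes the hydrogen-bond donor and the hydrogen-bond acceptor counted on the group that leaves and adds fluorine, gives a 1.3-fold lower number from compound 2 to compound 4 (0.12 log units; within the scatter). The same holds when 3-(trifluoromethyl)phenyl is compared with the two other groups at this position: 4-hydroxyphenyl gives a 1.1-fold lower number from compound 3 to compound 4 (0.06 log units; within the scatter), and amino gives a 1.7-fold lower number from compound 1 to compound 4 (0.24 log units; within the scatter), so a ring bearing neither a hydroxyl nor a nitrogen-linked amide also leaves the number within the scatter of all three earlier compounds. Nothing available explains why these four different groups give numbers so close together.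

The compounds shown leave open whether a group carrying a carboxylic acid or a tertiary amine on this double-bonded nitrogen would produce a step beyond the scatter. Since the shared core stays the same in all four compounds, they also leave open what a change elsewhere in the molecule, such as a longer chain in place of the group on the sulfonyl, would do in this assay.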